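Swapping the Aryl Group on a Sulfonyl Nitrogen

This account rests on a few compounds, and the source may have more. Where it says the series, first, only, none or still open, it means among the compounds named here.

Compound 1 `COc1ccc(-c2cc(=O)c3c(OC)cc(OC)cc3n2C)cc1`: "not determined" (no result reported)
Compound 2 `COc1ccc(-c2cc(=O)c3c(OC)cc(OC)cc3n2Cc2ccccc2)cc1`: > 17300 nM
Compound 3 `COc1ccc(-c2cc(=O)c3c(OC)cc(OC)cc3n2S(=O)(=O)c2c(F)c(F)c(F)c(F)c2F)cc1`: > 34400 nM

Three compounds share one core and differ only in the group attached to the ring nitrogen. In a functional assay on HepG2 cells (Homo sapiens) for antiproliferative activity, with a stated time of 72 h (on this read-out lower numbers stand for an effect already at smaller amounts and higher numbers for an effect only at larger amounts of compound), compound 1 gives "not determined" (no result reported). Compound 2 reaches only a limit of the assay, > 17300 nM. Compound 3 likewise stops at a limit, > 34400 nM. Compound 3 therefore stands where no number was obtained at all; the two values that exist for this series are both limits (the limit of > 17300 nM in this assay, at which 1 of the 3 values shown sits, and (the limit of > 34400 nM in this assay, at which 1 of the 3 values shown sits)), and one entry carries no result. Compound 4 `COc1ccc(-c2cc(=O)c3c(OC)cc(OC)cc3n2S(=O)(=O)c2ccc(OC)cc2)cc1` carries 4-methoxyphenyl in place of 2,3,4,5,6-pentafluorophenyl on a sulfonyl sulfur. Within the data shown here, no step between two compounds with real numbers exists here, so the data give no direction for this change. The expectation is that compound 4 again shows no effect within the reachable amounts of this assay. Compound 4 is expected near 35000 nM, within a range of 8000 nM to 150000 nM. This corresponds to an expected step that the limit leaves unreadable from compound 3 to compound 4, none beyond the scatter.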

Compound 4, half-maximal effective concentration: > 82700 nM
Compound 4: a limit, no number; the forecaster's own chance of this, stated with the estimate: 70%; middle value at least 2.3-fold (0.37 log units) away from the limit.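

Compound 4 also stops at a limit of the assay, so no step can be read from compound 3 to compound 4 or from compound 2 to compound 4. The compounds shown leave open whether any group on the aromatic nitrogen gives a measurable effect in this assay.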